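The compounds below may be only part of what the source reports. "The series", "measured", "known", "first", "only" and "open" are said of these compounds alone.

Measured in a functional assay on HeLa cells (Homo sapiens) for cytotoxicity, read by ELISA, with a stated time of 2 days; a lower number here means a stronger inhibitor, a higher number a weaker inhibitor:
- Compound 1 `Oc1ccc(-c2cc(-c3ccccc3)cc(-c3ccccc3)n2)cc1`: 1700 nM
- Compound 2 `Oc1ccc(-c2cc(-c3ccccc3)cc(-c3ccsc3)n2)cc1`: 17300 nM

Of these two compounds, compound 2 has the higher number at 17300 nM and is therefore the weaker inhibitor in this assay. Within the data shown here, compound 1, at 1700 nM, is its only neighbour.

Compound 3 `Oc1ccc(-c2cc(-c3ccccc3)cc(-c3ccco3)n2)cc1` has not yet been measured. It carries furan-2-yl in place of thiophen-3-yl on an aromatic carbon, next to the ring nitrogen: furan-2-yl in place of thiophen-3-yl on an aromatic carbon.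

Among the measured compounds shown here, only one measured step bears on this change. Thiophen-3-yl in place of phenyl at this same place gave a 10-fold higher number from compound 1 to compound 2 (1.01 log units; beyond the scatter), a large step. For the measured compounds named here, it shows that this place responds strongly to a change of ring, but no furan-2-yl compound has been measured. Both groups are five-membered aromatic rings with 1 hetero atom, so compound 3 is expected to stay closer to compound 2 than to compound 1, with any shift towards a lower number. The expected change is a 1.7-fold lower number from compound 2 to compound 3 (0.24 log units; within the scatter), which is a small step. Compound 3 is estimated at 10000 nM, with an expected range of 2500 nM to 35000 nM.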

Compound 3, half-maximal inhibitory concentration: 10900 nM
Compound 3: middle estimate off by 1.1-fold (0.04 log units), on the low side; low and high end bracket the measured number.
By their numbers in this assay, from the lowest: compound 1; then compounds 3 and 2 (each within the scatter of the next).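

The swap between the two five-membered aromatic rings, each with 1 hetero atom, gives a 1.6-fold lower number from compound 2 to compound 3 (0.20 log units; within the scatter) in this assay, so thiophen-3-yl and furan-2-yl cannot be told apart at this place on an aromatic carbon, next to the ring nitrogen. Measured against the phenyl group of compound 1, furan-2-yl gives a 6.4-fold higher number from compound 1 to compound 3 (0.81 log units; beyond the scatter), which means that the thiophen-3-yl result is no longer a single case: both five-membered rings give higher numbers than phenyl beyond the scatter, none of the three compounds goes against this, and compound 1 remains the strongest inhibitor of the three. Nothing shown here gives a reason for either step.

What the compounds leave open is whether the phenyl group is favoured as a six-membered ring or as a ring of carbon atoms alone, a question that a pyridin-3-yl group at this place would bear on directly. Going by these compounds, it also remains open how this place would respond to a group that is not an aromatic ring at all, such as an amine or a short alkyl chain.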